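A few compounds are considered here, and "the series" means these few. Any claim that something is new, unique, unknown or untested is made for them only; others in the source may bear on it.

Measured so far in a functional assay on HL-60 cells (Homo sapiens) for inhibition, read by MTT assay, with a stated time of 72 h; a higher number here means a weaker inhibitor, a lower number a stronger inhibitor:
compound 1 `CCc1nc(-c2ccccc2F)c(C(=O)N2CCN(c3cccc(Cl)c3)CC2)o1` gives 139 nM
compound 2 `Cc1nc(-c2ccccc2)c(C(=O)N2CCN(c3cccc(Cl)c3Cl)CC2)o1` gives 133 nM

Going by the values given here, compound 2, at 133 nM, stands within the scatter of compound 1, at 139 nM, so these two numbers give no order between the compounds. Both are the only reference points available for the next compound.

Compound 3 `Cc1ccc(N2CCN(C(=O)c3oc(C)nc3-c3ccccc3)CC2)c(C)c1` follows from compound 2 by one change, with 2,4-dimethylphenyl in place of 2,3-dichlorophenyl on an amine nitrogen in a ring. Among the compounds with values here, no measured step shows the effect of this replacement, so the expectation is only loosely anchored. The group that enters has the same ring type and the same count of heavy atoms as the group that leaves. In this assay, a small step towards a higher number is expected, not passing the scatter, and the range is kept wide to allow for a larger move in either direction. The expected change is a 1.4-fold higher number from compound 2 to compound 3 (0.13 log units; within the scatter). For compound 3 the estimated value is 180 nM, with an expected range of 60 nM to 550 nM.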

Compound 3, half-maximal inhibitory concentration: 101 nM
Beside the measured number, compound 3's estimate is 1.8-fold (0.25 log units) above it; the range from low to high includes it.
By their numbers in this assay, from the lowest: compounds 3, 2 and 1 (each within the scatter of the next).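

In this assay the first step readable at this position, on an amine nitrogen in a ring, is a 1.3-fold lower number from compound 2 to compound 3 (0.12 log units; within the scatter) and so gives no order between 2,3-dichlorophenyl and 2,4-dimethylphenyl. The exchange replaces both chlorine atoms with carbon and changes the substitution pattern, while the heavy-atom count, the six-membered aromatic ring of carbon only and the absence of hydrogen-bond donors and acceptors stay the same; within this one pair, these differences together leave the number within the scatter. Nothing at hand accounts for this step or assigns a contribution to either group.

The compounds shown leave open whether this insensitivity extends beyond these two substituted phenyl groups, for example to a phenyl group carrying a carboxylic acid or an amine, or to a longer alkyl chain in place of the aromatic ring. Since the two groups differ in both substituent type and pattern, the contribution of each single substituent also remains unresolved.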